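Aminoacyl sulfonamides: aryl substituent on the benzenesulfonyl ring

The source may report more compounds than this note shows. Statements on the series, on what has been measured and on what is new or still open speak of the compounds shown alone.

Compound 2 `CC(C)C[C@H](N)C(=O)NS(=O)(=O)c1ccccc1` is the unsubstituted parent of the series; in an assay on isolated protein for inhibition of leucine--tRNA ligase, cytoplasmic (Homo sapiens) (a higher number here means a weaker inhibitor, a lower number a stronger inhibitor), compound 2 gives 1100 nM. Compound 1 `CC(C)C[C@H](N)C(=O)NS(=O)(=O)c1cccc(-c2ccncc2)c1` carries a pyridin-4-yl on the same ring, and in this assay compound 1 gives 1200 nM. The two values lie within the scatter of each other, so the step of a 1.1-fold lower number from compound 1 to compound 2 (0.04 log units; within the scatter) shows that removing the pyridin-4-yl left the number essentially unchanged, and compound 2 sits alongside compound 1 rather than apart from it.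

Compound 3 `Cc1cc(-c2cccc(S(=O)(=O)NC(=O)[C@@H](N)CC(C)C)c2)nc(N)n1` differs from compound 2 by 2-amino-6-methylpyrimidin-4-yl in place of hydrogen on an aromatic carbon. Among the compounds with values here, the only step that bears on this change is a 1.1-fold lower number from compound 1 to compound 2 (0.04 log units; within the scatter), which was within the scatter; a second aryl substituent at the same aromatic carbon is therefore expected to give no step beyond the scatter in this assay. The estimate for compound 3 is 900 nM, with a range of 350 nM to 2300 nM, meaning an expected step of a 1.2-fold lower number from compound 2 to compound 3 (0.09 log units; within the scatter).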

Compound 3, half-maximal inhibitory concentration: 160 nM
Compound 3: the middle estimate sits 5.6-fold (0.75 log units) above what was measured, outside the stated range (below it).
By their numbers in this assay, from the lowest: compound 3; then compounds 2 and 1 (each within the scatter of the next).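

At this aromatic carbon, meta to a large group, the nature of the ring carried matters in this assay: 2-amino-6-methylpyrimidin-4-yl in place of hydrogen gives a 6.9-fold lower number from compound 2 to compound 3 (0.84 log units; beyond the scatter), and in place of pyridin-4-yl it gives a 7.5-fold lower number from compound 1 to compound 3 (0.88 log units; beyond the scatter), whereas the earlier exchange of pyridin-4-yl for hydrogen gave only a 1.1-fold lower number from compound 1 to compound 2 (0.04 log units; within the scatter), within the scatter. A six-membered aromatic ring at this carbon therefore does not by itself move the number; of the two rings shown, only 2-amino-6-methylpyrimidin-4-yl does. Nothing available explains the difference between these two rings.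

The compounds shown do not separate the amino group from the methyl group, as both enter together in compound 3. A 2-aminopyrimidin-4-yl or a 6-methylpyrimidin-4-yl at the same carbon would divide that step between them.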